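This account rests on a few compounds, and the source may have more. Where it says the series, first, only, none or still open, it means among the compounds named here.

Compound 1 `CCC(C)(C)Cc1c[nH]c(CCc2ccc(-c3cccc(C)n3)cc2)n1`: 105 nM
Compound 2 `CCC(C)(C)Cc1c[nH]c(CCc2ccc(-n3ncnn3)cc2)n1`: 422 nM

In a functional assay on HEK293 cells for agonist activity at Bombesin receptor subtype-3 (Homo sapiens), read by luminescence and calcium flux, with a stated time of 10 min (on this read-out lower numbers stand for an effect already at smaller amounts and higher numbers for an effect only at larger amounts of compound), compound 1 stands at the lower of the two numbers; the nearest is compound 2, reached by a step of a 4.0-fold higher number from compound 1 to compound 2 (0.60 log units; beyond the scatter), which exchanges one aromatic group for another at the same place. Compound 3 `CCC(C)(C)Cc1c[nH]c(CCc2ccc(-c3cnccn3)cc2)n1` differs from compound 1 as follows: pyrazin-2-yl in place of 6-methylpyridin-2-yl on an aromatic carbon. The step from compound 1 to compound 2 is the only one that bears on this exchange, and it was modest. A smaller step in the same direction is expected for compound 3, a 1.9-fold higher number from compound 1 to compound 3 (0.28 log units; within the scatter), because the entering ring keeps a six-membered shape unlike the tetrazole of compound 2 422 nM. Compound 3 is therefore estimated at 200 nM, within 80 nM to 600 nM.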

Compound 3, half-maximal effective concentration: 431 nM
Compound 3: the middle estimate sits 2.2-fold (0.33 log units) below what was measured, and the stated range covers the measured number.
By their numbers in this assay, from the lowest: compound 1; then compounds 2 and 3 (each within the scatter of the next).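

Keeping a six-membered aromatic ring at this place, para to a large group, did not hold the number: pyrazin-2-yl in place of 6-methylpyridin-2-yl gives a 4.1-fold higher number from compound 1 to compound 3 (0.61 log units; beyond the scatter) in this assay. The five-membered and six-membered replacements are not told apart, with a 1.0-fold higher number from compound 2 to compound 3 (0.01 log units; within the scatter) between them, so among these three compounds only 6-methylpyridin-2-yl stands apart. No measurement at hand gives a cause for these steps. Pyrazin-2-yl differs from 6-methylpyridin-2-yl both in lacking the methyl and in its second ring nitrogen, and the compounds shown do not separate the two. As far as these compounds go, how plain pyridin-2-yl, or an amine or a carboxylic acid, would behave at this place remains open.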